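A few compounds are considered here, and "the series" means these few. Any claim that something is new, unique, unknown or untested is made for them only; others in the source may bear on it.

For the measured compounds named here, in an ADME assay on BJ cells (Homo sapiens), read by MTT assay, with a stated time of 72 h (on this read-out lower numbers stand for stronger inhibition and higher numbers for weaker inhibition), compound 3 `Cc1ncnc2c1c(-c1cc3ccccc3o1)cn2[C@@H]1O[C@H](CO)[C@@H](O)[C@H]1O` gives 93900 nM, the highest number among the three compounds measured so far. Compound 1 `COc1nc(N)nc2c1c(-c1cc3ccccc3o1)cn2[C@@H]1O[C@H](CO)[C@@H](O)[C@H]1O` gives 25600 nM, and compound 2 `COc1ncnc2c1c(-c1ccco1)cn2[C@@H]1O[C@H](CO)[C@@H](O)[C@H]1O` gives 430 nM; both gaps from compound 3 lie beyond the usual scatter of repeated measurements. Compound 4 `COc1ncnc2c1c(-c1cc3ccccc3o1)cn2[C@@H]1O[C@H](CO)[C@@H](O)[C@H]1O` has not yet been measured in this assay. Compared with compound 3, compound 4 carries methoxy in place of methyl on an aromatic carbon. Going by the values given here, no measured pair differs in only this one place, so the size of this step is not known from the numbers at hand. Still, the two methoxy compounds both sit well below compound 3, so a moderate drop is expected, a step of a 7.8-fold lower number from compound 3 to compound 4 (0.89 log units; beyond the scatter). Compound 4 is estimated at 12000 nM, with a range from 2500 nM to 50000 nM.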

Compound 4, half-maximal inhibitory concentration: 22400 nM
The estimate for compound 4 lay 1.9-fold (0.27 log units) below the measured number; the range from low to high includes it.
By their numbers in this assay, from the lowest: compound 2; then compounds 4 and 1 (each within the scatter of the next); then compound 3.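

In this assay, for the compounds shown here, methoxy in place of methyl on this aromatic carbon gives a 4.2-fold lower number from compound 3 to compound 4 (0.62 log units; beyond the scatter) and so provides the first direct reading of this change. Hydrogen in place of amino on an aromatic carbon gives a 1.1-fold lower number from compound 1 to compound 4 (0.06 log units; within the scatter) and leaves the two compounds within the scatter, whereas 1-benzofuran-2-yl in place of furan-2-yl gives a 52-fold higher number from compound 2 to compound 4 (1.72 log units; beyond the scatter) as the largest of the three steps. As far as these compounds go, how an ethoxy group, a chlorine atom or an amine on the methoxy-bearing carbon would compare stays open. Nothing at hand explains the size of any of these steps.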